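Bromophenyl replaces pyrrolidinyl on the shared core

The compounds below may be only part of what the source reports. "The series", "measured", "known", "first", "only" and "open" are said of these compounds alone.

Measured compounds:
compound 1 `O=[N+]([O-])c1ccccc1CNc1cc(Br)cc2cn[nH]c12` — > 100000 nM (a limit)
compound 2 `Oc1ccc(CNc2cc(C(F)(F)F)cc3[nH]ncc23)cc1` — 36700 nM
compound 3 `FC(F)(F)c1cc(NC[C@H]2CCCN2)c2cn[nH]c2c1` — 9580 nM

In an assay for inhibition of Indoleamine 2,3-dioxygenase 1 (Homo sapiens), with stated times of 10 min and 60 min (a lower number here means a stronger inhibitor, a higher number a weaker inhibitor), compound 1 reaches only the limit > 100000 nM, which is a limit of the assay and not a number (the limit of > 100000 nM in this assay, at which 1 of the 3 values shown sits). Compound 2 gives 36700 nM. Compound 3 gives 9580 nM, the lowest of the two numbers, with compound 2 nearest; the two are separated by a 3.8-fold lower number from compound 2 to compound 3 (0.58 log units; beyond the scatter).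

Compound 4 `FC(F)(F)c1cc(NCc2cccc(Br)c2)c2cn[nH]c2c1` differs from compound 3 by 3-bromophenyl in place of pyrrolidin-2-yl on a saturated chain carbon bound to a nitrogen on an aromatic ring. For the measured compounds named here, the only measured step at this place is a 3.8-fold lower number from compound 2 to compound 3 (0.58 log units; beyond the scatter), in which the compound carrying an aromatic ring sat higher. Returning to an aromatic ring, an upward step beyond the scatter is expected for compound 4, a 3.1-fold higher number from compound 3 to compound 4 (0.50 log units; beyond the scatter). Compound 4 is therefore estimated at 30000 nM, within 8000 nM to 120000 nM.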

Compound 4, half-maximal inhibitory concentration: > 100000 nM
Compound 4 gave a limit, no number (the forecaster's own chance of this, stated with the estimate: 20%); middle value at least 3.3-fold (0.52 log units) from the limit.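

Compound 4 gives a limit of the assay and not a number: the limit of > 100000 nM in this assay, at which 2 of the 4 values shown sit. Replacing pyrrolidin-2-yl with 3-bromophenyl gives an at least 10-fold higher number from compound 3 to compound 4 (1.01 log units; beyond the scatter), and replacing 4-hydroxyphenyl with 3-bromophenyl gives an at least 2.7-fold higher number from compound 2 to compound 4 (0.43 log units; beyond the scatter). An aromatic ring at this place therefore has no single level, and what the ring carries also counts.

From the compounds shown here alone, whether the change follows the bromine itself or where it stands on the ring remains open. Also open, going by these compounds, is whether a piperidin-2-yl group or a 3-aminophenyl group would keep the number of compound 3.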